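This account rests on a few compounds, and the source may have more. Where it says the series, first, only, none or still open, it means among the compounds named here.

Of the compounds shown here, two with a shared core have been measured in a functional assay on DU-145 cells (Homo sapiens) for inhibition, read by trypan blue exclusion, with a stated time of 96 h; on this read-out lower numbers stand for stronger inhibition of growth and higher numbers for weaker inhibition of growth. Compound 1 `O=C(/C(=C\c1ccccc1OCc1ccccc1)S(=O)(=O)c1ccc(F)cc1)c1ccc(Cl)cc1` gives 1000 nM in this assay. Compound 2 `O=C(/C(=C\OCc1ccccc1)S(=O)(=O)c1ccccc1Cl)c1ccc(Cl)cc1`, which carries a different pair of groups on the same core, gives 1000 nM in this assay. At the digits shown the two stand level, and that gap lies within the usual scatter of repeated measurements, so nothing separates compound 1 from compound 2 on these numbers.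

A third compound, compound 3 `Cc1ccc(CS/C(=C/c2ccccc2OCc2ccccc2)C(=O)c2ccc(Cl)cc2)cc1`, has not yet been measured. It differs from compound 1 at a single place: (4-methylbenzyl)sulfanyl in place of (4-fluorophenyl)sulfonyl on a double-bonded chain carbon bound to a carbonyl carbon and a double-bonded chain carbon. Within the data shown here, no measured pair shows this particular change, so its effect cannot be read from the data and has to be judged from the change alone. The expectation is a small step toward weaker inhibition of growth, a 1.5-fold higher number from compound 1 to compound 3 (0.18 log units; within the scatter) in this assay, of a size near the edge of the usual scatter rather than clearly beyond it. Compound 3 is therefore expected to give about 1500 nM in this assay, with a range from 400 nM to 6000 nM.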

Compound 3, concentration for 50% growth inhibition: 1000 nM
For compound 3 the middle estimate is 1.5-fold (0.18 log units) above the measured one, within the range that was stated.
By their numbers in this assay, from the lowest: compounds 1, 2 and 3 (each within the scatter of the next).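

In this assay, among these compounds, putting (4-methylbenzyl)sulfanyl in place of (4-fluorophenyl)sulfonyl on a double-bonded chain carbon bound to a carbonyl carbon and a double-bonded chain carbon gives no change at the digits printed from compound 1 to compound 3 (within the scatter), the first step at this position that can be read. The exchange is far from trivial on paper: the two double bonds outside aromatic rings go, hydrogen-bond acceptors drop from 2 to 1, and fluorine gives way to a methyl group, yet the read-out does not separate the two compounds, so this position accepts both groups at this level of growth inhibition. No measurement here explains that result.

Going by these compounds, since the step combines several structural differences, it remains open which of them matter, and a (4-methylbenzyl)sulfonyl group at this place would help to separate the sulfonyl-to-sulfanyl exchange from the exchange of the aromatic group. Also open, on these data alone, is whether a quite different group at this place, such as an amine or a carboxylic acid, would shift the number beyond the scatter.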